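Alkyl carbamate series of aryl selenocyanates: chain-length notes

The compounds below may be only part of what the source reports. "The series", "measured", "known", "first", "only" and "open" are said of these compounds alone.

Measured so far:
compound 1 `CCCOC(=O)Nc1ccc([Se]C#N)cc1`, 28900 nM
compound 2 `CCCCCCOC(=O)Nc1ccc([Se]C#N)cc1`, 23600 nM

Both carry the same core and differ only in the alkyl group on the carbamate oxygen. In a functional assay on HTB-54 cells (Homo sapiens) for cytotoxicity, read by MTT assay, with a stated time of 72 h (a lower number here means a stronger inhibitor of growth, a higher number a weaker inhibitor of growth), compound 2 gives the lower of the two numbers, but the step of a 1.2-fold lower number from compound 1 to compound 2 (0.09 log units; within the scatter) is within the scatter, so no order between compound 1 and compound 2 can be read from these data.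

Compound 3 `CCOC(=O)Nc1ccc([Se]C#N)cc1` is not yet measured. The change from compound 2 to compound 3 is hydrogen in place of butyl on a saturated chain carbon, two bonds along the chain from an oxygen next to a carbonyl group: a shortening of the chain, running opposite to the lengthening seen between compound 1 and compound 2. Going by the values given here, the only step bearing on this, from compound 1 to compound 2, was within the scatter, which gives no ground to expect a step beyond the scatter here either. Compound 3 is therefore expected to read close to compound 2, with an estimated step of a 1.3-fold higher number from compound 2 to compound 3 (0.10 log units; within the scatter). The estimate for compound 3 in this assay is 30000 nM, with a range from 15000 nM to 60000 nM.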

Compound 3, concentration for 50% growth inhibition: 24900 nM
Compound 3: the middle estimate sits 1.2-fold (0.08 log units) above what was measured, within the range that was stated.
By their numbers in this assay, from the lowest: compounds 2, 3 and 1 (each within the scatter of the next).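

Working notes, chain length: in this assay, hydrogen in place of butyl on a saturated chain carbon, two bonds along the chain from an oxygen next to a carbonyl group, gives only a small step (a 1.1-fold higher number from compound 2 to compound 3 (0.02 log units; within the scatter)), and hydrogen in place of methyl at the same place also gives a small step (a 1.2-fold lower number from compound 1 to compound 3 (0.06 log units; within the scatter)). Going by these compounds alone, the single earlier step now has two companions, so all three pairs among the ethyl, propyl and hexyl carbamates sit within the scatter, whether butyl or methyl is the group that leaves. No measurement is at hand that would explain this flat reading.

From the compounds shown here alone, whether a chain longer than hexyl would move the number beyond the scatter stays open. The same holds for methyl on the carbamate oxygen, and for an amine or a carboxylic acid carried on the alkyl chain.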